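Cytotoxicity notes on a benzyl-substituted sulfonyl series

The source may report more compounds than this note shows. Statements on the series, on what has been measured and on what is new or still open speak of the compounds shown alone.

Going by the values given here, the series shares one core; compound 1 carries it as `O=S1(=O)N=C(OCc2ccccc2)c2ccccc2N1Cc1ccccc1` and is the only member with a numerical read-out in a functional assay on HEL cells (Homo sapiens) (on this read-out lower numbers stand for higher toxicity in this test and higher numbers for lower toxicity in this test), where compound 1 gives 200000 nM. Compound 2, `O=C1c2ccccc2N(Cc2ccccc2Cl)S(=O)(=O)N1Cc1ccccc1Cl`, returns only a limit in this assay: compound 2 gives > 20000 nM, which is a limit of the test and not a measured number. Compound 3, `O=C1c2ccccc2N(Cc2cccc(Cl)c2)S(=O)(=O)N1Cc1ccccc1`, likewise returns a limit: in this assay compound 3 gives > 5000 nM. Compound 2 thus stands among the members for which the test reports no number, as noted in the limit of > 20000 nM in this assay, at which 1 of the 3 values shown sits, beside one further limit, (the limit of > 5000 nM in this assay, at which 1 of the 3 values shown sits). No pair among these three differs in a single place, so no measured step exists.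

Compound 4, `O=C1c2ccccc2N(Cc2ccccc2Cl)S(=O)(=O)N1COCc1ccccc1`, is the unmeasured member. It follows from compound 2 by the change (benzyloxy in place of 2-chlorophenyl on a saturated chain carbon bound to an amide-type nitrogen in a ring). Among the compounds with values here, with no measured step to draw on, the expectation for compound 4 rests only on the limits that compound 2 and compound 3 show, and a step from compound 2 to compound 4 of about a number no higher from compound 2 to compound 4 (the limit leaves the size open) is expected, within the scatter. Compound 4 is therefore estimated at 20000 nM in this assay, with a range from 5000 nM to 100000 nM, most probably again reported only as a limit.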

Compound 4, minimum cytotoxic concentration: 200000 nM
Compound 4: middle estimate off by 10-fold (1.00 log units), on the low side; the measured number lies above the stated range.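

In this assay compound 2 gives > 20000 nM, which is a limit and not a number. No step can be read from compound 2 to compound 4, which gives 200000 nM. The compounds shown leave open how far benzyloxy in place of 2-chlorophenyl shifts the read-out in this assay.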